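A few compounds are considered here, and "the series" means these few. Any claim that something is new, unique, unknown or untested is made for them only; others in the source may bear on it.

Compound 1 `CCN(CC)CCN(C)c1ccc(Cn2c(=O)[nH]c3c(N)nc(C(F)(F)F)cc32)cn1` in an in vitro ADME assay on microsomes from liver (Homo sapiens) for pharmacokinetics; a higher number here means faster removal of the compound, a lower number slower removal: compound 1 gives 24 mL.min-1.g-1.
Compound 2 `Nc1nc(C(F)(F)F)cc2c1[nH]c(=O)n2Cc1ccc(NCCO)nc1`: for compound 2 the reading is a limit of the assay, < 8 mL.min-1.g-1.
Compound 3 `Nc1nc(C(F)(F)F)cc2c1[nH]c(=O)n2Cc1ccc(NCCN2CCCC2)nc1`: compound 3 gives 8.5 mL.min-1.g-1.

All three share one core and differ only in the group carried on the aromatic carbon of the pyridine-like ring. On the plain numbers, compound 3 stands lowest of the two, with compound 1 as its nearest neighbour at a 2.8-fold lower number from compound 1 to compound 3 (0.45 log units; beyond the scatter). Against compound 2 no order can be read, as the step of an at least 1.0-fold higher number from compound 2 to compound 3 (0.02 log units; that floor lies within the scatter) lies within the scatter.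

Compound 4 `CN(C)CCN(C)c1ccc(Cn2c(=O)[nH]c3c(N)nc(C(F)(F)F)cc32)cn1` has not yet been measured. It differs from compound 3 by one change: (2-(dimethylamino)ethyl)(methyl)amino in place of (2-(pyrrolidin-1-yl)ethyl)amino on an aromatic carbon. Within the data shown here, two measured steps bear on this. Among the measured compounds shown here, the step of a 2.8-fold lower number from compound 1 to compound 3 (0.45 log units; beyond the scatter) took the group of compound 1 to that of compound 3, and the change to compound 4 largely runs back the other way, toward a group that is close to but smaller than the one in compound 1. The step of an at least 3.0-fold lower number from compound 1 to compound 2 (0.47 log units; beyond the scatter) points the same way, with the open-chain group of compound 1 again giving the higher number.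

Compound 4 is therefore expected to move up: a 1.8-fold higher number from compound 3 to compound 4 (0.25 log units; within the scatter). The estimate for compound 4 is 15 mL.min-1.g-1, within 7 mL.min-1.g-1 to 30 mL.min-1.g-1.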

Compound 4, intrinsic clearance in microsomes: 16 mL.min-1.g-1
For compound 4 the middle estimate is 1.1-fold (0.03 log units) below the measured one; the range from low to high includes it.
By their numbers in this assay, from the lowest: compounds 3, 4 and 1 (each within the scatter of the next, the first and the last beyond it). At a limit, below all of these: compound 2.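

Replacing diethylamino with dimethylamino gives a 1.5-fold lower number from compound 1 to compound 4 (0.18 log units; within the scatter) in this assay, so compound 1 and compound 4 cannot be told apart by this step. Exchanging the ring-bearing (2-(pyrrolidin-1-yl)ethyl)amino for the open-chain (2-(dimethylamino)ethyl)(methyl)amino gives a 1.9-fold higher number from compound 3 to compound 4 (0.27 log units; within the scatter), which means that compound 4 cannot be told apart from either of the two compounds whose own gap lies beyond the scatter, and the earlier split into two clear levels now has a compound that fits neither. Compound 2 remains at a limit of the assay: the limit of < 8 mL.min-1.g-1 in this assay, at which 1 of the 4 values shown sits. The last step to read is an at least 2.0-fold higher number from compound 2 to compound 4 (0.30 log units; that floor lies within the scatter), and it allows no order to be stated for this pair.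

The step from compound 3 to compound 4 alters the ring and the methyl on the nitrogen together, so the compounds shown cannot say which of these two features accounts for any part of the gap between compound 1 and compound 3. From the compounds shown here alone, a (2-(dimethylamino)ethyl)amino group or a (2-(pyrrolidin-1-yl)ethyl)(methyl)amino group would vary one feature at a time, and a side chain ending in a morpholine ring or a carboxylic acid remains unexplored here.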